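Compound 2 to compound 4: a new group on the carbonyl

This account rests on a few compounds, and the source may have more. Where it says the series, first, only, none or still open, it means among the compounds named here.

Measured so far in a functional assay on liver (Rattus norvegicus, strain Sprague-Dawley) for inhibition, with a stated time of 1 h (a higher number here means a weaker inhibitor, a lower number a stronger inhibitor), and shown as values
- compound 1 `COc1cc(C2Oc3cc([C@H]4Oc5cc(O)cc(O)c5C(=O)[C@@H]4O)ccc3OC2COC(=O)c2cc(OC)c(OC)c(OC)c2)ccc1O` gives 25700 nM
- compound 2 `CCOC(=O)CC(=O)OCC1Oc2ccc([C@H]3Oc4cc(O)cc(O)c4C(=O)[C@@H]3O)cc2OC1c1ccc(O)c(OC)c1` gives 33400 nM
- compound 3 `COc1cc(C2Oc3cc([C@H]4Oc5cc(O)cc(O)c5C(=O)[C@@H]4O)ccc3OC2COC(=O)c2ccc(OC)c(OC)c2)ccc1O` gives 16000 nM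

Compound 2 and compound 1 share the upper end of these numbers, within the scatter of each other, and only compound 3 lies apart from compound 2. Compound 4 `COc1cc(C2Oc3cc([C@H]4Oc5cc(O)cc(O)c5C(=O)[C@@H]4O)ccc3OC2COC(=O)/C=C/c2ccc(Br)cc2)ccc1O` has not yet been measured. Its structure departs from compound 2 by one swap, 2-(4-bromophenyl)ethenyl in place of (ethoxycarbonyl)methyl on a carbonyl carbon which in words is 2-(4-bromophenyl)ethenyl in place of (ethoxycarbonyl)methyl on a carbonyl carbon.

Two measured steps change that same group. The step of a 1.3-fold higher number from compound 1 to compound 2 (0.11 log units; within the scatter) puts (ethoxycarbonyl)methyl in place of 3,4,5-trimethoxyphenyl, and the step of a 2.1-fold lower number from compound 2 to compound 3 (0.32 log units; beyond the scatter) puts 3,4-dimethoxyphenyl in place of (ethoxycarbonyl)methyl. Both swaps involve a group with an aromatic ring, as the incoming group of compound 4 does, and both are small. Within the data shown here, no measured compound carries 2-(4-bromophenyl)ethenyl, so this comparison is only a rough guide. In this assay a small move toward a lower number is expected, with a 1.7-fold lower number from compound 2 to compound 4 (0.22 log units; within the scatter) as the estimated step, and it may not clear the usual scatter. The expected value for compound 4 is 20000 nM with an estimated range of 8000 nM to 45000 nM on this reasoning.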

Compound 4, half-maximal inhibitory concentration: 16300 nM
For compound 4 the middle estimate is 1.2-fold (0.09 log units) above the measured one; low and high end bracket the measured number.
By their numbers in this assay, from the lowest: compounds 3, 4, 1 and 2 (each within the scatter of the next, the first and the last beyond it).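

In this assay, among these compounds, the change on this carbonyl carbon now yields a step that clears the scatter without involving compound 3 (a 2.0-fold lower number from compound 2 to compound 4 (0.31 log units; beyond the scatter)), and the incoming 2-(4-bromophenyl)ethenyl is the first group here with bromine and with a double bond joining the ring to the carbonyl. The two other ring-bearing groups give no readable difference from it (a 1.0-fold higher number from compound 3 to compound 4 (0.01 log units; within the scatter); a 1.6-fold lower number from compound 1 to compound 4 (0.20 log units; within the scatter)), so this position accepts three quite different ring-bearing groups with no separation among them, although a simple rule that a ring beats (ethoxycarbonyl)methyl fails, since compound 1 goes against it by staying within the scatter of compound 2. Nothing in the data given offers an explanation for the modest step.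

The result does not separate the contribution of the bromine from that of the ethenyl link, a question that a plain 2-phenylethenyl or a 2-(4-chlorophenyl)ethenyl on the same carbonyl carbon would address. On these data alone, it also remains open how this position would respond to an amine or a carboxylic acid at the end of a longer chain.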